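This account rests on a few compounds, and the source may have more. Where it says the series, first, only, none or still open, it means among the compounds named here.

Compound 1 `Oc1ccc(-c2cc(-c3ccc(C(F)(F)F)cc3)cc(-c3cccc(O)c3)n2)cc1` gives 17300 nM in a functional assay on HeLa cells (Homo sapiens) for inhibition; on this read-out higher numbers stand for weaker inhibition and lower numbers for stronger inhibition.
Compound 2 `Oc1ccc(-c2cc(-c3ccc(C(F)(F)F)cc3)cc(-c3ccc(O)cc3)n2)cc1` reaches only a limit in this assay, > 50000 nM, not a number.
Compound 3 `Oc1ccc(-c2cc(-c3ccccc3OC(F)(F)F)cc(-c3cccc(O)c3)n2)cc1` gives 5800 nM in this assay.

Of the two numbers read, compound 3 holds the lower one, and the gap to compound 1 lies beyond the scatter. The change from compound 1 to compound 2 is 4-hydroxyphenyl in place of 3-hydroxyphenyl on an aromatic carbon and made an at least 2.8-fold higher number from compound 1 to compound 2 (0.46 log units; beyond the scatter); the step is known only as a bound because compound 2 sits at the limit of > 50000 nM in this assay, at which 1 of the 3 values shown sits. Compound 4 `Oc1ccc(-c2cc(-c3ccccc3OC(F)(F)F)cc(-c3ccc(O)cc3)n2)cc1` differs from compound 3 by 4-hydroxyphenyl in place of 3-hydroxyphenyl on an aromatic carbon, the same kind of change, though here the place is meta to a large group rather than meta to a 4-(trifluoromethyl)phenyl group. The difference between the cores of compound 1 and compound 3 is not broken down here. Compound 4 is expected to show a weakening step of a 3.4-fold higher number from compound 3 to compound 4 (0.54 log units; beyond the scatter), resting on an at least 2.8-fold higher number from compound 1 to compound 2 (0.46 log units; beyond the scatter). For compound 4 the estimate is 20000 nM, expected between 8000 nM and 50000 nM.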

Compound 4, half-maximal inhibitory concentration: 44600 nM
Estimate against measurement, compound 4: 2.2-fold (0.35 log units) below, and the stated range covers the measured number.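

In this assay, 4-hydroxyphenyl in place of 3-hydroxyphenyl gave a 7.7-fold higher number from compound 3 to compound 4 (0.89 log units; beyond the scatter), so the change weakened inhibition on both cores shown: the same change on two cores in this assay, an at least 2.8-fold higher number (0.46 log units; beyond the scatter) from compound 1 to compound 2 and a 7.7-fold higher number (0.89 log units; beyond the scatter) from compound 3 to compound 4; the limit leaves it open whether they differ Compound 2 stands at a limit, > 50000 nM, and not at a number. The direction therefore carried from the core of compound 1 to the core of compound 3, but this does not show that the size of the step carried, and two cores do not make a rule for the whole series.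

The compounds shown leave open how an amine or a methoxy group in place of the hydroxyl would read in this assay. They also leave open whether the same step would appear on a core bearing a carboxylic acid.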